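Chloro on the Phenyl Sulfonyl of Compound 3

The compounds below may be only part of what the source reports. "The series", "measured", "known", "first", "only" and "open" are said of these compounds alone.

Measured compounds:
- compound 1, `O=S(=O)(c1cccc(F)c1)c1cn(C2CCNC2)c2ncccc12`: 2.7 nM
- compound 2, `CN1CCC(n2cc(S(=O)(=O)c3ccccc3)c3cccnc32)C1`: 2.5 nM
- compound 3, `O=S(=O)(c1ccccc1)c1cn(C2CCCNC2)c2ncccc12`: 4.9 nM

In an assay on HeLa cells for displacement of a labelled ligand from 5-hydroxytryptamine receptor 6 (Homo sapiens) (on this read-out higher numbers stand for weaker inhibition and lower numbers for stronger inhibition), compound 3 gives 4.9 nM, the highest of the three numbers, but its gaps to compound 1 and compound 2 both lie within the scatter, so the three compounds are not separated by this read-out. Among the measured compounds shown here, the one single-point step among them, a 2.0-fold higher number from compound 2 to compound 3 (0.29 log units; within the scatter), shows that swapping the saturated ring on the aromatic nitrogen left the number essentially where it was.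

Compound 4, `O=S(=O)(c1ccc(Cl)cc1)c1cn(C2CCCNC2)c2ncccc12`, differs from compound 3 by chloro in place of hydrogen on an aromatic carbon, placed para to a large group. For the measured compounds named here, no measured step touches this position. Compound 1 carries a fluoro on the same phenyl ring, at a different position and with another saturated ring, and gives 2.7 nM, close to compound 3; beyond that there is no guide. The expected step is therefore small, a 1.2-fold lower number from compound 3 to compound 4 (0.09 log units; within the scatter), in no clear direction. Compound 4 is expected to give about 4 nM, between 1.3 nM and 12 nM.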

Compound 4, inhibition constant: 7.6 nM
Compound 4: the middle estimate sits 1.9-fold (0.28 log units) below what was measured, within the range that was stated.
By their numbers in this assay, from the lowest: compounds 2, 1, 3 and 4 (each within the scatter of the next, the first and the last beyond it).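

Replacing phenyl with 4-chlorophenyl gives a 1.6-fold higher number from compound 3 to compound 4 (0.19 log units; within the scatter) in this assay, so the two compounds cannot be told apart on this read-out. Among the compounds shown here, compounds 1, 2 and 3 all carry hydrogen at this place, and compound 4 gives the first reading with a heavier atom there, showing that a chloro on this aromatic carbon, para to a large group, still leaves a low nanomolar number. No supporting measurement among the data shown accounts for this result.

What the compounds shown leave open is whether this place would accept a different kind of group, such as methoxy, an amine or a carboxylic acid, and still stay within the scatter. Going by these compounds, it also remains open whether chloro behaves the same way elsewhere on the ring, or with the saturated rings of compound 1 and compound 2.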